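A few compounds are considered here, and "the series" means these few. Any claim that something is new, unique, unknown or untested is made for them only; others in the source may bear on it.

Working notes on the series.

Three compounds are measured in a functional assay on EKVX cells (Homo sapiens) for cytotoxicity, read by sulforhodamine B assay, with a stated time of 48 h; a higher number here means that more compound is tolerated, a lower number that less compound is tolerated. Compound 1 `ClCc1cccc(Cn2cnc3c(Cl)ncnc32)c1` gives 63100 nM. Compound 2 `ClCc1cccc(Cn2cnc3c(Cl)nc(Cl)nc32)c1` gives 6450 nM. Compound 3 `ClCc1ccccc1Cn1cnc2ncnc(Cl)c21` gives 45700 nM; against compound 1 it lies within the scatter, against compound 2 it lies beyond it.

Compound 1 and compound 3 are built from the same atoms joined differently; the difference between the two cores is not broken down here.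

For the measured compounds named here, the one counted step is chloro in place of hydrogen on an aromatic carbon, made on the core of compound 1, and it gave a 9.8-fold lower number from compound 1 to compound 2 (0.99 log units; beyond the scatter).

Compound 4 `ClCc1ccccc1Cn1cnc2nc(Cl)nc(Cl)c21` is not yet measured. Against compound 3 the change is chloro in place of hydrogen on an aromatic carbon. The place of the incoming chloro is described in the same words for both pairs, so this is the same change, made this time on the core of compound 3.

Going by the values given here, the expectation for compound 4 in this assay rests on the single earlier instance, a 9.8-fold lower number from compound 1 to compound 2 (0.99 log units; beyond the scatter), so a step of about an 8.3-fold lower number from compound 3 to compound 4 (0.92 log units; beyond the scatter) is estimated, with wide uncertainty since one example on a different core is thin ground. For compound 4 the estimate in this assay is 5500 nM, expected to fall between 2500 nM and 13000 nM.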

Compound 4, concentration lethal to 50% of the cells: 6020 nM
Beside the measured number, compound 4's estimate is 1.1-fold (0.04 log units) below it; measured number inside the range.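

In this assay, chloro in place of hydrogen on the aromatic carbon between two ring nitrogen atoms gave a 7.6-fold lower number from compound 3 to compound 4 (0.88 log units; beyond the scatter), and the size of the step carried over from one core to the other with no difference that can be told apart: the same change on two cores in this assay, a 9.8-fold lower number (0.99 log units; beyond the scatter) from compound 1 to compound 2 and a 7.6-fold lower number (0.88 log units; beyond the scatter) from compound 3 to compound 4, 1.3-fold (0.11 log units) apart, within the scatter of two such steps. For the compounds shown here, this is a consistent result, but it rests on only two pairs, and their cores are built from the same atoms joined differently. It does not show that the step would keep its size on a more distant core or in another assay, and it does not explain why the number falls.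

The compounds shown leave open whether an amine or a methoxy group at that same place would give a step of similar size or direction. They also leave open how the step would behave if the chloromethyl group gave way to a longer chain or a carboxylic acid.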